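Chloro for methyl on the indole ring of compound 2

The source may report more compounds than this note shows. Statements on the series, on what has been measured and on what is new or still open speak of the compounds shown alone.

Measured so far:
compound 1, `COC(=O)[C@@]1(C)CCC=C2[C@@H]1CC[C@@H](C)[C@]2(C)Cc1c[nH]c2ccc(Cl)cc12`: 17000 nM
compound 2, `COC(=O)[C@@]1(C)CCC=C2[C@@H]1CC[C@@H](C)[C@]2(C)Cc1c(C)[nH]c2ccc(C)cc12`: 25000 nM

In a functional assay on HBL-100 cells (Homo sapiens) for inhibition, read by sulforhodamine B assay, with a stated time of 48 h (on this read-out higher numbers stand for weaker inhibition of growth and lower numbers for stronger inhibition of growth), compound 2 gives 25000 nM, the highest of the two numbers; compound 1 gives 17000 nM, within the scatter of compound 2. Among the compounds with values here, the pair differs in two places, so no single step can be drawn from it. Compound 3, `COC(=O)[C@@]1(C)CCC=C2[C@@H]1CC[C@@H](C)[C@]2(C)Cc1c(C)[nH]c2ccc(Cl)cc12`, carries chloro in place of methyl on an aromatic carbon, and shares the chloro of compound 1. Within the data shown here, no step of this kind has been measured in this assay; a change no larger than the scatter is expected, a 1.3-fold lower number from compound 2 to compound 3 (0.10 log units; within the scatter). For compound 3 the estimate is 20000 nM, expected between 8000 nM and 50000 nM.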

Compound 3, concentration for 50% growth inhibition: 15000 nM
The estimate for compound 3 lay 1.3-fold (0.12 log units) above the measured number, and the stated range covers the measured number.
By their numbers in this assay, from the lowest: compounds 3, 1 and 2 (each within the scatter of the next).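

In this assay, chloro in place of methyl on the aromatic carbon gives a 1.7-fold lower number from compound 2 to compound 3 (0.22 log units; within the scatter), so this position now has a comparison that differs in one place, and the exchange stays inside the scatter. Methyl in place of hydrogen on an aromatic carbon gives a 1.1-fold lower number from compound 1 to compound 3 (0.05 log units; within the scatter), so this change also stays inside the scatter. No supporting data bear on either step.

From the compounds shown here alone, whether an amine, a carboxylic acid or a longer chain on the aromatic carbon that carries the chloro would give a step beyond the scatter remains open.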